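This account rests on a few compounds, and the source may have more. Where it says the series, first, only, none or still open, it means among the compounds named here.

Measured compounds and their oral bioavailability:

Compound 1, `O=[N+]([O-])c1cccc(NS(=O)(=O)c2ccc3nc(-c4ccccc4)c(-c4ccccc4)nc3c2)c1`: 85.6%
Compound 2, `O=S(=O)(Nc1ccccn1)c1ccc2nc(-c3ccccc3)c(-c3ccccc3)nc2c1`: 100%
Compound 3, `O=[N+]([O-])c1ccc(NS(=O)(=O)c2ccc3nc(-c4ccccc4)c(-c4ccccc4)nc3c2)cc1`: 87.6%

In an ADME assay on the whole organism for pharmacokinetics, with Homo sapiens as the target (on this read-out lower numbers stand for lower oral bioavailability and higher numbers for higher oral bioavailability), compound 3 gives 87.6%, the second highest of the three numbers. Its nearest neighbour is compound 1: the change a number 2 percentage points higher from compound 1 to compound 3 (within the scatter) lies within the scatter, so the two cannot be told apart. Compound 2 stands further away, with the step of a number 12.4 percentage points lower from compound 2 to compound 3 (beyond the scatter).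

Compound 4, `O=S(=O)(Nc1cccc2ccccc12)c1ccc2nc(-c3ccccc3)c(-c3ccccc3)nc2c1`, has not yet been measured in this assay. It differs from compound 3 in one place: naphthalen-1-yl in place of 4-nitrophenyl on a sulfonamide nitrogen.

Among the measured compounds shown here, two measured steps bear on this, both being exchanges of the group on the sulfonamide nitrogen. Moving the nitro group around the ring, a number 2 percentage points higher from compound 1 to compound 3 (within the scatter), did nothing beyond the scatter, while trading pyridin-2-yl for 4-nitrophenyl, a number 12.4 percentage points lower from compound 2 to compound 3 (beyond the scatter), gave a modest drop. For the measured compounds named here, no measured step exchanges a nitrophenyl for a naphthalen-1-yl, so the direction is uncertain; the exchanges seen so far have been modest at most, and a similar size or none beyond the scatter is expected here, as the step of a number 2.6 percentage points lower from compound 3 to compound 4 (within the scatter). For compound 4 the estimated value in this assay is 85%, with a range from 65% to 100%.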

Compound 4, oral bioavailability: 100%
Compound 4: the middle estimate sits 15 percentage points below what was measured; measured number inside the range.
By their numbers in this assay, from the lowest: compounds 1 and 3 (each within the scatter of the next); then compounds 2 and 4 (each within the scatter of the next).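

In this assay, the step of a number 12.4 percentage points higher from compound 3 to compound 4 (beyond the scatter) and the step of a number 14.4 percentage points higher from compound 1 to compound 4 (beyond the scatter) show that a group made of carbon only, naphthalen-1-yl, can sit on the sulfonamide nitrogen and give a higher number than either nitrophenyl group. The step of no change at the digits printed from compound 2 to compound 4 (within the scatter) adds that pyridin-2-yl is not alone in reaching the top of this series, so a ring nitrogen in this group is not needed for such a number. Across the four compounds, the two nitrophenyl compounds form the lower pair and the pyridin-2-yl and naphthalen-1-yl compounds the upper pair, with no compound going against this split, but no measurement at hand explains it.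

The compounds shown leave open whether the lower pair reflects the nitro group itself or the single carbon ring that carries it, and a plain phenyl group would help to separate the two. On these data alone, it also remains open how an amine or a carboxylic acid in place of the nitro group, or a longer chain on the sulfonamide nitrogen, would fall relative to these two pairs.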